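The source may hold more compounds than are shown below. What is called first, only, known or untested is meant among the compounds shown, and "the series" means these compounds.

Measured so far in a functional assay on DU-145 cells (Homo sapiens) for inhibition, read by trypan blue exclusion, with a stated time of 96 h; on this read-out higher numbers stand for weaker inhibition of growth and lower numbers for stronger inhibition of growth:
- compound 1 `O=C(/C(=C\c1ccc(O)cc1O)Sc1ccc(Br)cc1)c1ccc(Cl)cc1`: 50000 nM
- compound 2 `CN(C)c1ccc(/C=C(\C(=O)c2ccc(Br)cc2)S(=O)(=O)Cc2ccc(F)cc2)cc1`: 50000 nM
- compound 3 `Cc1ccc(S(=O)(=O)/C(=C/c2ccc(N(C)C)cc2)C(=O)c2ccc(Br)cc2)cc1`: 50000 nM

Compound 2 stands level with compound 1 and compound 3 at the digits recorded; the three values sit within the scatter of one another, so no order can be read among them. Within the data shown here, the one single-place step in the set is no change at the digits printed from compound 2 to compound 3 (within the scatter), 4-methylphenyl in place of 4-fluorobenzyl on a sulfonyl sulfur, and it moves nothing. Compound 1 and compound 2 differ in more than one place, so only their two values can be set side by side, and those two values agree.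

Compound 4 `O=C(/C(=C\c1ccc(Br)cc1)S(=O)(=O)Cc1ccc(F)cc1)c1ccc(Br)cc1` differs from compound 2 in one place: bromo in place of dimethylamino on an aromatic carbon. Among the measured compounds shown here, no measured step touches the ring bearing the dimethylamino group; the step from compound 2 to compound 3 sits on the sulfonyl side and is flat within the scatter. There is therefore nothing in the measured data that points to a move in either direction, and the expectation for this assay is a step of no size beyond the scatter, no change at the digits printed from compound 2 to compound 4 (within the scatter). On that basis compound 4 is estimated at 50000 nM, with a range from 25000 nM to 100000 nM.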

Compound 4, concentration for 50% growth inhibition: 25000 nM
For compound 4 the middle estimate is 2.0-fold (0.30 log units) above the measured one, and the stated range covers the measured number.
By their numbers in this assay, from the lowest: compounds 4, 1, 2 and 3 (each within the scatter of the next).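

Bromo in place of dimethylamino, on an aromatic carbon para to a large group, is the only single-place change shown on this ring, and in this assay it reads as (a 2.0-fold lower number from compound 2 to compound 4 (0.30 log units; within the scatter)). The exchange of 4-(dimethylamino)phenyl for 4-bromophenyl, from a group of 3 heavy atoms with a hydrogen-bond acceptor to a single bromine, therefore leaves the read-out within the scatter, as does the change on the sulfonyl sulfur (no change at the digits printed from compound 2 to compound 3 (within the scatter)). No measurement is available that bears on the behaviour of this position.

Going by these compounds, whether this carbon can shift growth inhibition beyond the scatter stays open, since a primary amine, a carboxylic acid or a longer alkyl chain there could read differently from both dimethylamino and bromo. Also open is whether the flat reading at this position carries over when 4-methylphenyl rather than 4-fluorobenzyl sits on the sulfonyl sulfur, as the bromo group is shown here only with 4-fluorobenzyl.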